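4-Methylpiperazin-1-yl Replaces Chloro in Compound 4

The source may report more compounds than this note shows. Statements on the series, on what has been measured and on what is new or still open speak of the compounds shown alone.

Measured compounds, with their values in a functional assay on G-361 cells (Homo sapiens) for cytotoxicity, read by MTT assay, with a stated time of 3 days; a higher number here means a weaker inhibitor, a lower number a stronger inhibitor:
Compound 1, `N#Cc1c(Cl)nc(SCc2nc3ccccc3[nH]2)nc1-c1ccccc1`, gives 12.5 nM.
Compound 2, `N#Cc1c(NN)nc(SCc2nc3ccccc3[nH]2)nc1-c1ccccc1`, gives 14.7 nM.
Compound 3, `N#Cc1c(-c2ccccc2)nc(SCc2nc3ccccc3[nH]2)nc1N1CCNCC1`, gives 2.5 nM.

Among these three numbers compound 1 stands second highest. Its nearest neighbour is compound 2, with a 1.2-fold higher number from compound 1 to compound 2 (0.07 log units; within the scatter), a gap too small to read as a change. The furthest is compound 3, with a 5.0-fold lower number from compound 1 to compound 3 (0.70 log units; beyond the scatter), a modest gain that is real.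

The unmeasured compound 4, `CN1CCN(c2nc(SCc3nc4ccccc4[nH]3)nc(-c3ccccc3)c2C#N)CC1`, differs from compound 1 in one spot: 4-methylpiperazin-1-yl in place of chloro on an aromatic carbon. Among the measured compounds shown here, two measured steps bear on this change, since both exchange a small substituent for piperazin-1-yl: a 5.0-fold lower number from compound 1 to compound 3 (0.70 log units; beyond the scatter) and a 5.9-fold lower number from compound 2 to compound 3 (0.77 log units; beyond the scatter). Both were modest gains beyond the scatter. The entering group in compound 4 differs from that of compound 3 only by its methyl, and nothing measured here tells how that methyl acts. A step of similar size in the same direction is therefore expected, a 3.6-fold lower number from compound 1 to compound 4 (0.55 log units; beyond the scatter), with some room for the methyl to blunt part of it. Compound 4 is thus estimated at 3.5 nM, with a likely range from 1.2 nM to 10 nM.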

Compound 4, half-maximal inhibitory concentration: 14.7 nM
Estimate against measurement, compound 4: 4.2-fold (0.62 log units) below; the measured number lies above the stated range.
By their numbers in this assay, from the lowest: compound 3; then compounds 1, 2 and 4 (each within the scatter of the next).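

The earlier compounds shown here suggested that a piperazine ring on this aromatic carbon brings a lower number, but in this assay the addition of one methyl on the ring's amine nitrogen takes that gain away, with a 5.9-fold higher number from compound 3 to compound 4 (0.77 log units; beyond the scatter). The ring alone is therefore not enough: 4-methylpiperazin-1-yl in place of chloro gives a 1.2-fold higher number from compound 1 to compound 4 (0.07 log units; within the scatter), and in place of aminoamino it gives no change at the digits printed from compound 2 to compound 4 (within the scatter), so this much larger group performs no differently from either small one. At this position, then, a change at the far end of the entering group, on the amine nitrogen and well away from the aromatic carbon, decides whether compound 3's lower number is kept.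

From the compounds shown here alone, it remains open whether the methyl is special or whether any group on that nitrogen would do the same, which an ethyl, an acetyl or a longer chain there could show, as could a morpholine ring in place of the piperazine. Nothing shown here gives a reason why the methyl has this effect.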